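Biaryl ether series: fluoro-methylphenyl isomer under expectation

The compounds below may be only part of what the source reports. "The series", "measured", "known", "first", "only" and "open" are said of these compounds alone.

Measured compounds:
- compound 1 `COc1ccccc1-c1cccc(COc2ccc([C@H](CC(=O)O)c3nccn3C)cc2)c1`: "not determined" (no result reported)
- compound 2 `Cc1ccc(F)cc1-c1cccc(COc2ccc([C@H](CC(=O)O)c3nccn3C)cc2)c1`: 42000 nM
- compound 3 `COc1ccc(-c2cccc(COc3ccc([C@H](CC(=O)O)c4nccn4C)cc3)c2)cc1`: "not determined" (no result reported)

Working notes. Within the data shown here, in an assay on CHO cells for agonist activity at Free fatty acid receptor 1 (Homo sapiens), read by luminescence, with a stated time of 20 s, in the presence of a further agent that is not named here (a lower number here means that less compound is needed, a higher number that more compound is needed for the effect), compound 2 gives 42000 nM and is the only member of the series with a number. Among the measured compounds shown here, for compound 1 this assay reports no result, and the same holds for compound 3: compound 3 stands without a number, and so does one further entry, so no step between measured compounds can be read off and nothing is known about the direction from compound 3 onwards.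

Compound 4 `Cc1cc(F)ccc1-c1cccc(COc2ccc([C@H](CC(=O)O)c3nccn3C)cc2)c1` is the next entry, still to be measured in this assay. It differs from compound 3 by 4-fluoro-2-methylphenyl in place of 4-methoxyphenyl on an aromatic carbon — in words, 4-fluoro-2-methylphenyl in place of 4-methoxyphenyl on an aromatic carbon. For the measured compounds named here, since compound 3 carries no number, no size of step can be stated for this change; what remains as a reference point is compound 2, whose group likewise carries a fluorine and a methyl on the same ring and which in this assay gives 42000 nM.

On that basis compound 4 is expected to sit near 40000 nM, with a range from 10000 nM to 150000 nM, and there is a real chance that this assay again reports only a limit or no number.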

Compound 4, half-maximal effective concentration: 21000 nM
Estimate against measurement, compound 4: 1.9-fold (0.28 log units) above, within the range that was stated.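

Exchanging 5-fluoro-2-methylphenyl for 4-fluoro-2-methylphenyl gives a 2.0-fold lower number from compound 2 to compound 4 (0.30 log units; within the scatter) in this assay, so on this evidence the two isomers cannot be told apart and the place of the fluorine on this ring has no readable effect on the number. Among these compounds, this is the first comparison that can be read at this position, whereas the steps involving compound 1 and compound 3 cannot be read, including the exchange of 4-methoxyphenyl for 4-fluoro-2-methylphenyl, since neither compound has a number. Nothing available bears on the reason for this result.

The compounds shown leave open whether this ring tolerates any change that moves the number beyond the scatter, since only two isomers with the same fluorine and methyl substituents can be compared so far. They also leave open what an amine, a hydroxyl or a carboxylic acid on this ring, or a plain unsubstituted phenyl in place of the substituted ring, would give in this assay.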